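This account rests on a few compounds, and the source may have more. Where it says the series, first, only, none or still open, it means among the compounds named here.

Measured in a functional assay on NCI-H460 cells (Homo sapiens) for inhibition, read by MTT assay, with a stated time of 24 h, tested at 0.1 ug/mL; a lower number here means less inhibition of growth, a higher number more inhibition of growth at the concentration tested:
- compound 1 (`O=C(CCCCC1CCSS1)NO`): 3.9%
- compound 2 (`O=C(CCCCC1CCSS1)Nc1cccc(C(F)(F)F)c1`): "not active" (no number reported)
- compound 3 (`O=C(CCCCC1CCSS1)Nc1ccc(OC(F)(F)F)cc1`): 7.05%

Only two of these compounds have a number. Compound 1 gives 3.9% and compound 3 gives 7.05%, and these two values lie within the usual scatter of each other. Compound 2 was reported as "not active" (no number reported), without a number.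

The next compound, compound 4 (`O=C(CCCCC1CCSS1)Nc1ccccn1`), has yet to be measured in this assay. It differs from compound 1 by pyridin-2-yl in place of hydroxy on an amide-type nitrogen. Among the measured compounds shown here, no step between measured compounds that differ in one place is available to size this change. The expectation therefore rests on the two compounds that also carry an aromatic ring at this nitrogen, compound 3 at 7.05% and compound 2 at "not active" (no number reported). On that basis, no step beyond the scatter is expected, in either direction. The expected change is a number 2.1 percentage points higher from compound 1 to compound 4 (within the scatter). For compound 4 the estimated value is 6%, with an expected range of 0% to 16%.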

Compound 4, percent growth inhibition at one concentration: 2.61%
Compound 4: middle estimate off by 3.4 percentage points, on the high side; the measured number falls inside the stated range.
By their numbers in this assay, from the lowest: compounds 4, 1 and 3 (each within the scatter of the next).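

Among the compounds shown here, the replacement of hydroxy by pyridin-2-yl on the amide-type nitrogen provides the first step that can be sized at this position in this assay (a number 1.3 percentage points lower from compound 1 to compound 4 (within the scatter)). A six-membered aromatic ring with one hetero atom, carrying no hydrogen-bond donor, can therefore take the place of hydroxy here without a step beyond the scatter. For this pair, the hydroxy is thus not shown to be needed for the growth inhibition seen at the concentration tested, and no available measurement explains the result.

Going by these compounds, the numbers so far all lie within the scatter of the next, so it remains open whether any group on this nitrogen can produce a larger step. A plain phenyl ring, a benzyl group or a longer chain ending in an amine or a carboxylic acid could test this.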